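A few compounds are considered here, and "the series" means these few. Any claim that something is new, unique, unknown or untested is made for them only; others in the source may bear on it.

Compound 3 `c1ccc(-c2ncc[nH]2)c(OCC2=NCCN2)c1` gives 100 nM in a functional assay for activation of Alpha-1A adrenergic receptor (Homo sapiens), read by calcium flux (on this read-out higher numbers stand for an effect only at larger amounts of compound and lower numbers for an effect already at smaller amounts), and stands highest of the two numbers recorded for the series. Compound 1 `c1ccc(-c2cnccn2)c(OCC2=NCCN2)c1` gives 2.51 nM in this assay, and the step of a 40-fold higher number from compound 1 to compound 3 (1.60 log units; beyond the scatter) separates the two. For compound 2 `c1ccc(-c2ccncn2)c(OCC2=NCCN2)c1` this assay reports only a limit, < 100000 nM. The steps a step that the limit leaves unreadable from compound 1 to compound 2 and a step that the limit leaves unreadable from compound 2 to compound 3 consequently cannot be sized.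

Compound 4 `Cc1ccoc1-c1ccccc1OCC1=NCCN1` differs from compound 3 in one place: 3-methylfuran-2-yl in place of 1H-imidazol-2-yl on an aromatic carbon. Among the compounds with values here, no measured step pairs a furan with any of the other heteroaryl groups, so nothing bears directly on this change. What the series does show is that exchanging one heteroaryl for another on this aromatic carbon can move the number a long way, as a 40-fold higher number from compound 1 to compound 3 (1.60 log units; beyond the scatter) illustrates, while the pair containing compound 2 shows that it can also push the value out of the readable window. The direction for a 3-methylfuran-2-yl is therefore open.

Compound 4 is expected at about 40 nM in this assay, with a wide range from 4 nM to 600 nM. The expected step for compound 4, a 2.5-fold lower number from compound 3 to compound 4 (0.40 log units; beyond the scatter), leans toward lower numbers, resting on compound 1, whose heteroaryl carries no donor and which gives 2.51 nM.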

Compound 4, half-maximal effective concentration: 3.16 nM
The estimate for compound 4 lay 13-fold (1.10 log units) above the measured number; the measured number lies below the stated range.
By their numbers in this assay, from the lowest: compounds 1 and 4 (each within the scatter of the next); then compound 3.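

In this assay the change to 3-methylfuran-2-yl on this aromatic carbon gives a 32-fold lower number from compound 3 to compound 4 (1.50 log units; beyond the scatter), so a five-membered aromatic ring at this place is compatible with a low number, which compound 3 alone could not show. With a 1.3-fold higher number from compound 1 to compound 4 (0.10 log units; within the scatter), a furan and a pyrazine stand level here, so a low number at this position is not confined to the six-membered pyrazin-2-yl, and among the readable values it is the 1H-imidazol-2-yl of compound 3, the group carrying a hydrogen-bond donor, that stands apart. The value of compound 2 is a limit, and the steps that involve it cannot be read: the limit of < 100000 nM in this assay, at which 1 of the 4 values shown sits.

The 3-methylfuran-2-yl brings a methyl and a furan at once, so the share of each in this step stays unresolved, and a plain furan-2-yl or a thiophene would be needed to separate them. With only four groups at this position, the compounds also cannot say whether the donor of compound 3 accounts for its higher number, a question that an N-methylimidazole would bear on directly.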